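Salicylanilide nitrile series: trifluoromethyl replacing methyl

This account rests on a few compounds, and the source may have more. Where it says the series, first, only, none or still open, it means among the compounds named here.

Measured so far in a functional assay on HL-60 cells (Homo sapiens) for cytotoxicity, read by luminescence and CellTiter-Glo, with a stated time of 3 days; on this read-out lower numbers stand for stronger inhibition and higher numbers for weaker inhibition:
- compound 1 `N#Cc1ccc(NC(=O)c2ccc(F)cc2O)cc1`: 1380 nM
- compound 2 `Cc1ccc(C(=O)Nc2ccc(C#N)cc2)c(O)c1`: 2420 nM
- compound 3 `N#Cc1ccc(NC(=O)c2cc(-c3ccncc3)ccc2O)cc1`: 5410 nM

Compound 2 stands second highest of the three numbers; its step to compound 1 is within the scatter, its gap to compound 3 is beyond it.

The step to compound 4 `N#Cc1ccc(NC(=O)c2ccc(C(F)(F)F)cc2O)cc1` is trifluoromethyl in place of methyl on an aromatic carbon.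

Within the data shown here, one measured step bears on this position: a 1.8-fold higher number from compound 1 to compound 2 (0.24 log units; within the scatter). Exchange of a small group at this place therefore moved the number only within the scatter; compound 3 shows that a much larger group here gives a higher number. For compound 4 no step beyond the scatter is expected, a 1.0-fold higher number from compound 2 to compound 4 (0.01 log units; within the scatter). Compound 4 is estimated at 2500 nM, range 1000 nM to 6000 nM in this assay.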

Compound 4, half-maximal inhibitory concentration: 1030 nM
Compound 4: the middle estimate sits 2.4-fold (0.39 log units) above what was measured; measured number inside the range.
By their numbers in this assay, from the lowest: compounds 4, 1 and 2 (each within the scatter of the next, the first and the last beyond it); then compound 3.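

In this assay, among these compounds, trifluoromethyl gives the first step beyond the scatter among the small groups at this position: a 2.3-fold lower number from compound 2 to compound 4 (0.37 log units; beyond the scatter), a modest one. The change from fluoro stays within the scatter, with a 1.3-fold lower number from compound 1 to compound 4 (0.13 log units; within the scatter), so trifluoromethyl and fluoro cannot be told apart here, while only methyl and trifluoromethyl separate. No measurement at hand accounts for either step.

From the compounds shown here alone, how an amine or a carboxylic acid at this place would compare remains open. So does the point between these small groups and the larger group of compound 3 at which the number begins to rise.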